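Methyl in place of fluoro on compound 2

This account rests on a few compounds, and the source may have more. Where it says the series, first, only, none or still open, it means among the compounds named here.

Values in a functional assay on Jurkat cells (Homo sapiens) for inhibition, read by MTT assay, with a stated time of 72 h; on this read-out higher numbers stand for weaker inhibition and lower numbers for stronger inhibition:
compound 1 `COc1cc(NC(=O)/C=C/c2cccc(OCc3ccccc3)c2)cc(OC)c1OC`: 3500 nM
compound 2 `C=C(Br)C(=O)Nc1cccc(/C=C/C(=O)Nc2ccc(F)cc2)c1`: 6200 nM
compound 3 `C=C(Br)C(=O)Nc1cccc(/C=C/C(=O)Nc2cccc(F)c2)c1`: 1000 nM
compound 4 `C=C(Br)C(=O)Nc1cccc(/C=C/C(=O)Nc2ccc(C)cc2)c1`: not yet measured

Compound 2, at 6200 nM, sits at the top end of the measured numbers, level within the scatter with compound 1 at 3500 nM. Compound 3 lies clearly lower, at 1000 nM.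

The change under consideration leads to compound 4: methyl in place of fluoro on an aromatic carbon. In words, this is methyl in place of fluoro on an aromatic carbon, para to a large group.

Within the data shown here, only one measured step touches this part of the molecule: a 6.2-fold lower number from compound 2 to compound 3 (0.79 log units; beyond the scatter). That step swaps 4-fluorophenyl for 3-fluorophenyl, so it shows that the number can respond to a change on this ring. Among the measured compounds shown here, it does not replace fluoro with another group, and no measured pair does. It therefore gives a rough upper guide to size and no direction.

A modest step at most is expected in this assay, with a slight lean towards a lower number, as compound 2 already stands at 6200 nM. No shift clearly beyond the scatter is expected, and the estimated change is a 1.4-fold lower number from compound 2 to compound 4 (0.14 log units; within the scatter). The expected value for compound 4 is 4500 nM, with an estimated range of 1800 nM to 10000 nM.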

Compound 4, half-maximal inhibitory concentration: 240 nM
For compound 4 the middle estimate is 19-fold (1.27 log units) above the measured one; the whole stated range lies above it.
By their numbers in this assay, from the lowest: compound 4; then compound 3; then compounds 1 and 2 (each within the scatter of the next).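

In this assay, methyl in place of fluoro on an aromatic carbon, para to a large group, gives a 26-fold lower number from compound 2 to compound 4 (1.41 log units; beyond the scatter) and is the first step shown that replaces fluoro with another group, so the identity of the group on this ring can move the number as well as its placement. The 4-methylphenyl ring also goes clearly past the 3-fluorophenyl ring, with a 4.2-fold lower number from compound 3 to compound 4 (0.62 log units; beyond the scatter) in the same read-out, so within this set of three amide-nitrogen aryl groups the lowest number belongs to the methyl compound and not to either fluorophenyl compound. No measurement shown accounts for this difference, and the steps stand here as observations only.

As far as these compounds go, whether an ethyl group, a longer chain, a methoxy group or an amine at this position would keep the number as low as in compound 4 stays open. Also open is whether methyl in place of fluoro on the 3-fluorophenyl ring of compound 3 would give a step of similar size and direction, since only the 4-fluorophenyl case is shown.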